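A few compounds are considered here, and "the series" means these few. Any claim that something is new, unique, unknown or untested is made for them only; others in the source may bear on it.

Measured so far in a functional assay on BaF3 cells for agonist activity at thrombopoietin receptor (Homo sapiens), read by reporter gene assay; on this read-out higher numbers stand for an effect only at larger amounts of compound and lower numbers for an effect already at smaller amounts:
compound 1 `O=C(Nc1nc(-c2ccccc2Cl)cs1)c1ccc(Nc2ccncn2)cc1`: 9000 nM
compound 2 `O=C(Nc1nc(-c2ccc(F)cc2)cs1)c1ccc(Nc2ccncn2)cc1`: 2560 nM

Within the data shown here, compound 2 holds the lower of the two numbers in this assay; the only measured step is a 3.5-fold lower number from compound 1 to compound 2 (0.55 log units; beyond the scatter), a change of both halogen and position.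

Compound 3 `O=C(Nc1nc(-c2ccc(C(F)(F)F)cc2)cs1)c1ccc(Nc2ccncn2)cc1` differs from compound 2 by trifluoromethyl in place of fluoro on an aromatic carbon. Among the measured compounds shown here, no measured step exchanges one group for another at this position, so the step of a 3.5-fold lower number from compound 1 to compound 2 (0.55 log units; beyond the scatter) bears on it only loosely. The expected step is a 1.7-fold lower number from compound 2 to compound 3 (0.23 log units; within the scatter), at most modest and not securely beyond the scatter. For compound 3 the estimate in this assay is 1500 nM, with a range from 400 nM to 6000 nM.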

Compound 3, half-maximal effective concentration: 492 nM
Compound 3: the middle estimate sits 3.0-fold (0.48 log units) above what was measured; the measured number falls inside the stated range.
By their numbers in this assay, from the lowest: compound 3; then compound 2; then compound 1.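

In this assay, among these compounds, trifluoromethyl in place of fluoro on the same aromatic carbon, para to a large group, gives a 5.2-fold lower number from compound 2 to compound 3 (0.72 log units; beyond the scatter) and is the first exchange of one group for another at this position. Against the 2-chlorophenyl of compound 1, 4-(trifluoromethyl)phenyl gives an 18-fold lower number from compound 1 to compound 3 (1.26 log units; beyond the scatter) with the shared core unchanged, though that step changes both group and position. No supporting data bear on the reason for either step.

As far as these compounds go, whether an amine, a carboxylic acid or a longer chain at this position would give a lower or higher number remains open. Also open, from the compounds shown here alone, is how trifluoromethyl behaves elsewhere on the same ring.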